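Swapping Bromine for Iodine in Two Calpain-1 Scaffolds

The source may hold more compounds than are shown below. What is called first, only, known or untested is meant among the compounds shown, and "the series" means these compounds.

Three compounds have been measured:
Compound 1 `O=C(O)/C(S)=C/c1c[nH]c2ccc(I)cc12` gives 90 nM.
Compound 2 `O=C(O)/C(S)=C/c1c[nH]c2ccc(Br)cc12` gives 20 nM.
Compound 3 `O=C(O)/C(S)=C/c1ccccc1Br` gives 9100 nM.

These numbers come from an assay on isolated protein for inhibition of Calpain-1 catalytic subunit (Sus scrofa); a lower number here means a stronger inhibitor, a higher number a weaker inhibitor. Compound 2 has the lowest number, and the change to compound 1 is iodo in place of bromo on an aromatic carbon, which gave a 4.5-fold higher number from compound 2 to compound 1 (0.65 log units; beyond the scatter). Compound 3 stands far higher than both: its number lies well beyond the scatter above compound 1 and further still above compound 2. How the core of compound 3 differs from the core of compound 2 is not broken down here.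

Compound 4 `O=C(O)/C(S)=C/c1ccccc1I` has not yet been measured. It differs from compound 3 by iodo in place of bromo on an aromatic carbon. Going by the values given here, this is the same kind of change as the one from compound 2 to compound 1, but the surroundings differ: in compound 1 the carbon is part of a fused or bridged system of two rings, meta to a fused ring and para to a fused ring, whereas in compound 4 it is ortho to a group of 6 heavy atoms on a ring of carbon only. Because the earlier step was a 4.5-fold higher number from compound 2 to compound 1 (0.65 log units; beyond the scatter), a similar weakening is expected here, estimated at a 2.7-fold higher number from compound 3 to compound 4 (0.44 log units; beyond the scatter). Compound 4 is therefore expected to give about 25000 nM in this assay, with a likely range from 6000 nM to 100000 nM.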

Compound 4, half-maximal inhibitory concentration: 42800 nM
Compound 4: the middle estimate sits 1.7-fold (0.23 log units) below what was measured; the measured number falls inside the stated range.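

In this assay, the new step is a 4.7-fold higher number from compound 3 to compound 4 (0.67 log units; beyond the scatter). Set beside the earlier case, putting iodo in place of bromo raises the number by a similar amount on both cores, and the two steps cannot be told apart: the same change on two cores in this assay, a 4.5-fold higher number (0.65 log units; beyond the scatter) from compound 2 to compound 1 and a 4.7-fold higher number (0.67 log units; beyond the scatter) from compound 3 to compound 4, 1.0-fold (0.02 log units) apart, within the scatter of two such steps. Going by these compounds alone, this shows that the size of the step carried over from the core of compound 2 to the core of compound 3, but with only two pairs it does not show that the same size would hold on a third core, and it does not explain why the step is so similar.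

The compounds shown leave open what a chloro or fluoro group would do in place of bromo on either core, and so whether the numbers follow any order across the halogens beyond these two. They also leave open whether the step would stay the same if a methyl ester replaced the carboxylic acid.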